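A few compounds are considered here, and "the series" means these few. Any claim that something is new, unique, unknown or untested is made for them only; others in the source may bear on it.

Measured compounds in the series:

compound 1, `Cc1cc(Nc2cc(Cl)cc(Cl)c2)nc(N)n1`: 27%
compound 2, `Cc1cc(Nc2cc(Cl)cc(C#N)c2)nc(N)n1`: 29%

In an assay on cells for inhibition of S-adenosylmethionine decarboxylase proenzyme (Homo sapiens), read by mass spectrometry, at pH 7.2, tested at 180 uM (a lower number here means less inhibition, a higher number more inhibition at the concentration tested (going by the name of the read-out)), compound 1 gives 27% and compound 2 gives 29%. On the two numbers shown compound 2 stands at the top, its nearest neighbour being compound 1; the only measured step, a number 2 percentage points higher from compound 1 to compound 2 (within the scatter), lies within the scatter, so the two compounds are not told apart by this assay.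

The next compound, compound 3, `Cc1cc(Nc2cc(Cl)cc(C(F)(F)F)c2)nc(N)n1`, has not yet been measured. It differs from compound 2 in one place: trifluoromethyl in place of cyano on an aromatic carbon

Going by the values given here, the single measured step bears on this change only loosely: it exchanged one group for another on the same aromatic carbon, and it moved the read-out by an amount within the scatter. Among the compounds with values here, no measured compound carries a trifluoromethyl group, so nothing shows how that group behaves here. Within the data shown here, the expectation therefore rests on the small size of the one known step: the estimated move from compound 2 to compound 3 is a number 1 percentage points lower from compound 2 to compound 3 (within the scatter), which is no step beyond the scatter in either direction. For compound 3 the estimated read-out in this assay is 28%, with a range from 12% to 44%.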

Compound 3, a percentage reported as inhibition, at one concentration (the size of the read-out at that concentration, not a potency): 39%
The estimate for compound 3 lay 11 percentage points below the measured number; measured number inside the range.
By their numbers in this assay, from the lowest: compounds 1, 2 and 3 (each within the scatter of the next, the first and the last beyond it).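

In this assay the series now holds a step that can be told apart: a number 12 percentage points higher from compound 1 to compound 3 (beyond the scatter), a chloro group giving way to trifluoromethyl, which shows that the read-out responds, modestly, to the group at this position. Going by these compounds alone, the other new step, a number 10 percentage points higher from compound 2 to compound 3 (within the scatter), does not separate trifluoromethyl from cyano, so compound 2 stays within the scatter of both compound 1 and compound 3, and the response at this position rests on the single exchange of chloro for trifluoromethyl. No measurement bearing on what lies behind this difference is available.

Open, going by these compounds, is whether an amine, a carboxylic acid or a longer chain on this aromatic carbon would move the read-out further than trifluoromethyl does, or in the other direction. Also open, on these data alone, is whether the difference seen at one tested concentration would hold as a difference in potency, since a percentage of this kind gives no potency for any of the three compounds.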